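Replacing the Indoline Cap of a Dithiocarbamate Benzamide

The source may hold more compounds than are shown below. What is called first, only, known or untested is meant among the compounds shown, and "the series" means these compounds.

Among the compounds with values here, all three compounds measured so far share one core: an aminophenyl benzamide joined through a sulfur-bearing linker to a thiocarbonyl carbon that carries a nitrogen group. They differ only in that nitrogen group. In a functional assay on A-375 cells (Homo sapiens) for antiproliferative activity, read by CCK-8 assay, with a stated time of 72 h, tested at 8 uM (on this read-out higher numbers stand for a stronger effect at the one concentration tested and lower numbers for a weaker effect), compound 2 `Nc1ccccc1NC(=O)c1ccc(CSC(=S)N2CCc3cc(Cl)ccc32)cc1` gives 82.3%, the highest of the three numbers. Compound 3 `Nc1ccccc1NC(=O)c1ccc(CSC(=S)N(Cc2ccccc2)Cc2ccccc2)cc1` gives 32.5% in this assay, and compound 1 `Nc1ccccc1NC(=O)c1ccc(CSC(=S)N2CCN(C(c3ccccc3)c3ccccc3)CC2)cc1` gives 8.4%, both beyond the scatter below compound 2.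

Compound 4 `CN(Cc1cccnc1)C(=S)SCc1ccc(C(=O)Nc2ccccc2N)cc1` has not been measured. It differs from compound 2 in one place: methyl((pyridin-3-yl)methyl)amino in place of 5-chloro-2,3-dihydro-1H-indol-1-yl on a thiocarbonyl carbon. Within the data shown here, no measured pair makes exactly this kind of exchange, so the size of the step cannot be read from the data. The two other nitrogen groups seen here, in compound 3 and compound 1, both fall well short of compound 2, and compound 4 is expected to do the same, with a downward step of a number 47.3 percentage points lower from compound 2 to compound 4 (beyond the scatter). Compound 4 is therefore estimated at 35%, in a range from 10% to 65%.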

Compound 4, a percentage reported as inhibition, at one concentration (the size of the read-out at that concentration, not a potency): 83.8%
Beside the measured number, compound 4's estimate is 48.8 percentage points below it, outside the stated range (above it).
By their numbers in this assay, from the lowest: compound 1; then compound 3; then compounds 2 and 4 (each within the scatter of the next).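

Exchanging 5-chloro-2,3-dihydro-1H-indol-1-yl for methyl((pyridin-3-yl)methyl)amino on a thiocarbonyl carbon gives, in this assay, a number 1.5 percentage points higher from compound 2 to compound 4 (within the scatter). A high number at this position is therefore not tied to the chlorine or to the five-membered non-aromatic ring, both of which leave with the old group, and it also holds with a six-membered aromatic ring that has a hetero atom. The position still does not accept every nitrogen group: compound 3 gives 32.5% and compound 1 gives 8.4% on the same read-out.

Going by these compounds, it remains open whether a morpholine or a plain dimethylamino group on the same carbon would keep the number this high. Nothing available explains why the groups of compound 2 and compound 4 read alike.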